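The source may report more compounds than this note shows. Statements on the series, on what has been measured and on what is new or still open speak of the compounds shown alone.

Compound 2 `COc1cc2c(Oc3ccc(NC(=O)c4cn(-c5c(C)cccc5C)nn4)cc3F)ccnc2cc1OCCCN1CCC(C)CC1` is measured in a functional assay on A549 cells (Homo sapiens) for cytotoxicity, read by MTT assay, with a stated time of 72 h; a lower number here means a stronger inhibitor, a higher number a weaker inhibitor; in this assay compound 2 gives 3340 nM.
Compound 3 `COc1cc2c(Oc3ccc(NC(=O)c4cn(-c5ccccc5)nn4)cc3F)ccnc2cc1OCCCN1CCN(C)CC1` gives 160 nM in this assay.
Compound 1 `COc1cc2c(Oc3ccc(NC(=O)c4cn(-c5c(C)cccc5C)nn4)cc3F)ccnc2cc1OCCCN1CCCCC1` has "not determined" (no result reported) in this assay.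

Among the two numbers available, compound 3 holds the lower one, and its gap to compound 2 lies beyond the usual scatter of this assay. Compounds 2 and 3 differ in two places at once, at the group on the triazole nitrogen and at the end of the side chain, so the pair on its own does not tell how much either change contributes.

Compound 4 `COc1cc2c(Oc3ccc(NC(=O)c4cn(-c5c(C)cccc5C)nn4)cc3F)ccnc2cc1OCCCN1CCN(C)CC1` is compound 3 with 2,6-dimethylphenyl in place of phenyl on an aromatic nitrogen. Going by the values given here, the same 2,6-dimethylphenyl group is present in compound 2, which holds the higher of the two numbers in this assay, but compound 2 also carries a different chain end, so no single step isolates this change. The step is expected to go toward a higher number, of size a 5.0-fold higher number from compound 3 to compound 4 (0.70 log units; beyond the scatter), because compound 2 bearing the same group gives 3340 nM while compound 3 gives 160 nM. With the chain end of compound 3 kept, the expectation is a loss smaller than that whole gap. Compound 4 is therefore estimated at 800 nM, within a range of 200 nM to 3500 nM.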

Compound 4, half-maximal inhibitory concentration: 2180 nM
The estimate for compound 4 lay 2.7-fold (0.44 log units) below the measured number, within the range that was stated.
By their numbers in this assay, from the lowest: compound 3; then compounds 4 and 2 (each within the scatter of the next).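

With the chain end held as 4-methylpiperazin-1-yl, 2,6-dimethylphenyl in place of phenyl on the aromatic nitrogen gives a 14-fold higher number from compound 3 to compound 4 (1.13 log units; beyond the scatter) in this assay, so the change at this position can now be read on its own, and it is large. Going by these compounds alone, with 2,6-dimethylphenyl held instead, 4-methylpiperazin-1-yl in place of 4-methylpiperidin-1-yl gives a 1.5-fold lower number from compound 2 to compound 4 (0.19 log units; within the scatter), which means that of the two changes separating the earlier pair, only the one on the aromatic nitrogen has a step beyond the scatter. Nothing measured here accounts for the size of the step at the aromatic nitrogen.

The compounds shown leave open whether a single methyl group, as in 2-methylphenyl, would already give a step of this size, or whether the loss follows from having two groups on the ring, as a 2,6-dichlorophenyl group could help to tell. They also leave open whether the chain end stays as silent with phenyl on the aromatic nitrogen, for instance with 4-methylpiperidin-1-yl or a morpholine there.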